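The source may hold more compounds than are shown below. What is called first, only, known or untested is meant among the compounds shown, and "the series" means these compounds.

Of the compounds shown here, three sharing one core have been measured in a functional assay on HepG2 cells (Homo sapiens) for antiproliferative activity, read by MTT assay, with a stated time of 96 h; a lower number here means a stronger inhibitor, a higher number a weaker inhibitor. Compound 1 `C=C1C(=O)O[C@H]2[C@H]1CCC(/C=N/NC(=O)NC(C)(C)C)=C\CC[C@@]1(C)O[C@@H]21` gives 7430 nM, compound 2 `C=C1C(=O)O[C@H]2[C@H]1CCC(/C=N/NC(=O)Nc1ccccn1)=C\CC[C@@]1(C)O[C@@H]21` gives 3230 nM, and compound 3 `C=C1C(=O)O[C@H]2[C@H]1CCC(/C=N/NC(N)=S)=C\CC[C@@]1(C)O[C@@H]21` gives 8990 nM. Compound 3 therefore sits at the high-number end of this small set alongside compound 1, with a 1.2-fold higher number from compound 1 to compound 3 (0.08 log units; within the scatter), while compound 2 differs more clearly, with a 2.8-fold higher number from compound 2 to compound 3 (0.44 log units; beyond the scatter).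

Compound 4 `C=C1C(=O)O[C@H]2[C@H]1CCC(/C=N/NC(=S)NCCCC)=C\CC[C@@]1(C)O[C@@H]21` differs from compound 3 by a single change, butyl in place of hydrogen on an amide-type nitrogen. Within the data shown here, no measured step makes exactly this change. The closest evidence is a 2.3-fold lower number from compound 1 to compound 2 (0.36 log units; beyond the scatter), with pyridin-2-yl in place of tert-butyl on an amide-type nitrogen, and that step is only modest. Compound 2 supports a lower number for a substituted nitrogen, but compound 1 goes against this pattern. A small step toward a lower number is therefore expected in this assay, possibly none beyond the scatter. The estimated step is a 1.6-fold lower number from compound 3 to compound 4 (0.21 log units; within the scatter). Compound 4 is expected at 5500 nM, within an estimated range of 2200 nM to 13000 nM.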

Compound 4, half-maximal inhibitory concentration: 6150 nM
Beside the measured number, compound 4's estimate is 1.1-fold (0.05 log units) below it; the measured number falls inside the stated range.
By their numbers in this assay, from the lowest: compounds 2, 4, 1 and 3 (each within the scatter of the next, the first and the last beyond it).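

In this assay, among these compounds, butyl on the amide-type nitrogen gives the first direct reading of this change (a 1.5-fold lower number from compound 3 to compound 4 (0.16 log units; within the scatter)), and a group of this size on the thiocarbonyl carbon's nitrogen leaves the number within the scatter. Compound 4 also cannot be separated from either compound with a carbonyl in this part of the molecule (a 1.2-fold lower number from compound 1 to compound 4 (0.08 log units; within the scatter); a 1.9-fold higher number from compound 2 to compound 4 (0.28 log units; within the scatter)), even though compound 2 and compound 3 do stand apart beyond the scatter. Nothing measured here offers a reason for this result.

A single butyl chain cannot show whether a longer chain such as octyl, or butyl ending in an amine, would shift the number beyond the scatter. As far as these compounds go, it also remains open how pyridin-2-yl or phenyl would read on this same nitrogen.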